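The source may hold more compounds than are shown below. What is called first, only, known or untested is meant among the compounds shown, and "the series" means these compounds.

Measured compounds in the series:

Compound 1, `Cc1cc(C(=O)N2CCCCc3ccccc32)ccc1CNC(=O)Nc1ccccc1F`, in a functional assay on HEK293 cells for agonist activity at Vasopressin V2 receptor (Homo sapiens), read by a luciferase reporter and cAMP accumulation (a higher number here means that more compound is needed for the effect, a lower number that less compound is needed), compound 1 gives 30 nM.
Compound 2, `Cc1cc(C(=O)N2CCCCc3ccccc32)ccc1CNC(=O)NCC(=O)N1CCCC1`, in this assay compound 2 gives 100 nM.
Compound 3, `Cc1cc(C(=O)N2CCCCc3ccccc32)ccc1CNC(=O)NCC(=O)N1CCCCC1`, in this assay compound 3 gives 150 nM.

Compound 3 carries the highest of the three numbers. Its nearest neighbour is compound 2, the step of a 1.5-fold higher number from compound 2 to compound 3 (0.18 log units; within the scatter) lying within the scatter, so the two cannot be ordered. The step of a 5.0-fold higher number from compound 1 to compound 3 (0.70 log units; beyond the scatter) is beyond the scatter, as is a 3.3-fold higher number from compound 1 to compound 2 (0.52 log units; beyond the scatter): replacing the 2-fluorophenyl on the urea nitrogen by either carbonylmethyl group costs a modest amount.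

Compound 4, `Cc1cc(C(=O)N2CCCCc3ccccc32)ccc1CNC(=O)N1CCC[C@H]1C(=S)N(C)C`, is the next compound. The change from compound 3 is a group of 10 heavy atoms (7 carbon, 2 nitrogen, 1 sulfur; one five-membered non-aromatic ring with 1 hetero atom) in place of a group of 10 heavy atoms (7 carbon, 2 nitrogen, 1 oxygen; one six-membered non-aromatic ring with 1 hetero atom), on a carbonyl carbon. The entering group has no hydrogen-bond donor, where the leaving group has one; the chain is folded into a five-membered ring and the carbonyl gives way to a thioamide. Of the measured steps, only a 1.5-fold higher number from compound 2 to compound 3 (0.18 log units; within the scatter) concerns a ring-size change of this kind, and it stayed within the scatter. Within the data shown here, no measured step covers the loss of the urea hydrogen or the thioamide, so the direction is open. Compound 4 is therefore expected near compound 3 or somewhat higher, the estimate being 200 nM with a range of 60 nM to 700 nM, a step of a 1.3-fold higher number from compound 3 to compound 4 (0.12 log units; within the scatter) expected.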

Compound 4, half-maximal effective concentration: 3.2 nM
The estimate for compound 4 lay 63-fold (1.80 log units) above the measured number, outside the stated range (below it).
By their numbers in this assay, from the lowest: compound 4; then compound 1; then compounds 2 and 3 (each within the scatter of the next).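

In this assay, among these compounds, this position on a carbonyl carbon had so far only raised the number relative to the 2-fluorophenyl urea, but the new group shows that it can also lower it sharply, with a 47-fold lower number from compound 3 to compound 4 (1.67 log units; beyond the scatter) and a 31-fold lower number from compound 2 to compound 4 (1.49 log units; beyond the scatter), both large steps. The gain also carries past the aryl group, with a 9.4-fold lower number from compound 1 to compound 4 (0.97 log units; beyond the scatter), so a non-aromatic group at this position can outperform the 2-fluorophenyl group, and compound 4 has the lowest number of the four, beyond the scatter from each of the others. The change combines several differences in one step: a thioamide, the nitrogen of the urea placed within a five-membered ring, no hydrogen-bond donor in the entering group and a defined stereocentre, and nothing available here accounts for the gain or separates these contributions.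

Which of these differences carries the gain remains open, and a dimethylamide with a carbonyl oxygen in place of the thioamide sulfur would test one of them directly. As far as these compounds go, the opposite configuration at the stereocentre and a piperidine ring in place of the five-membered ring also remain open.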